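Amino chain variation on the shared core

A few compounds are considered here, and "the series" means these few. Any claim that something is new, unique, unknown or untested is made for them only; others in the source may bear on it.

Measured compounds:
compound 1 `CCCN(C)c1cc(C)nc2c(-c3ccc(Cl)cc3Cl)nn(C)c12`, 24 nM
compound 2 `CCCCN(CCCC)c1cc(C)nc2c(-c3ccc(Cl)cc3Cl)nn(C)c12`, 0.62 nM

In an assay on HEK293 cells for displacement of a labelled ligand from corticotropin-releasing factor receptor 1 (Homo sapiens) (on this read-out higher numbers stand for weaker inhibition and lower numbers for stronger inhibition), compound 2 gives the lowest of the two numbers. For the measured compounds named here, the only measured step, a 39-fold lower number from compound 1 to compound 2 (1.59 log units; beyond the scatter), is the single neighbour of compound 2 on this read-out and leaves compound 1 well apart from it.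

Compound 3 `CCCCN(CCCOC)c1cc(C)nc2c(-c3ccc(Cl)cc3Cl)nn(C)c12` differs from compound 2 by methoxy in place of methyl on a saturated chain carbon, three bonds along the chain from a nitrogen on an aromatic ring. Going by the values given here, no measured step covers this kind of change. The step of a 39-fold lower number from compound 1 to compound 2 (1.59 log units; beyond the scatter) concerns the two alkyl groups on the ring nitrogen and was large, so the read-out is clearly responsive to this part of the molecule, but that step altered the chains themselves, whereas the change to compound 3 keeps the butyl chain on one side and exchanges a single terminal methyl on the other for methoxy. With nothing measured on methoxy here, the expectation for compound 3 is a step near the scatter, if anything toward a higher number, a 1.9-fold higher number from compound 2 to compound 3 (0.29 log units; within the scatter). For compound 3 the estimated value is 1.2 nM, within a range from 0.4 nM to 4 nM.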

Compound 3, inhibition constant: 18 nM
Compound 3: middle estimate off by 15-fold (1.18 log units), on the low side, and the stated range ends below it.
By their numbers in this assay, from the lowest: compound 2; then compounds 3 and 1 (each within the scatter of the next).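

In this assay, the end of the chain is not a silent position: methoxy in place of methyl, on a saturated chain carbon three bonds along the chain from a nitrogen on an aromatic ring, gives a 29-fold higher number from compound 2 to compound 3 (1.46 log units; beyond the scatter) and is a large step. The earlier step, a 39-fold lower number from compound 1 to compound 2 (1.59 log units; beyond the scatter) with dibutylamino in place of methyl(propyl)amino, changed both alkyl groups at once, whereas this one shows that a change confined to one chain end, butyl to 3-methoxypropyl with the other butyl chain kept, is enough to produce a large step on its own. Nothing available on these compounds accounts for the size of this step.

On these data alone, it remains open whether the step follows from the oxygen itself or from where it sits in the chain, a question that a 2-methoxyethyl chain, a pentyl chain or a terminal hydroxyl group in the same place could help to separate. Also open, as far as these compounds go, is how a second 3-methoxypropyl chain, in place of the remaining butyl, would read in this assay on the shared core.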